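This account rests on a few compounds, and the source may have more. Where it says the series, first, only, none or still open, it means among the compounds named here.

Measured compounds:
- Compound 1, `O=S(=O)(Nc1ncc(C(Oc2ccc3cc(Br)ccc3c2)c2ccc(Cl)cc2)s1)c1ccccc1`, in an ADME assay on HepG2 2.2.15 cells (Homo sapiens) for cytotoxicity (a lower number here means that less compound is tolerated, a higher number that more compound is tolerated), gives > 50000 nM, which is a limit of the assay rather than a number.
- Compound 2, `CCc1ccc(S(=O)(=O)Nc2ncc(C(Oc3ccc4cc(Br)ccc4c3)c3ccc(Cl)cc3)s2)cc1`, in this assay gives > 50000 nM, again a limit of the assay.
- Compound 3, `O=S(=O)(Nc1ncc(C(Oc2ccc3cc(Br)ccc3c2)c2ccc(Cl)cc2)s1)c1ccc(Cl)nc1`, in this assay is reported as "not toxic" (no number reported), with no number attached.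

Among the compounds with values here, compound 3 therefore stands nowhere on a numerical scale: the two further values around it are both limits, and the only step between measured compounds, a step that the two limits leave unreadable from compound 1 to compound 2, is an ethyl in place of hydrogen on an aromatic carbon whose size the two limits leave unreadable. Within the data shown here, the one piece of evidence is the limit of > 50000 nM in this assay, at which 2 of the 3 values shown sit.

Compound 4, `O=S(=O)(Nc1ncc(C(Oc2ccc3cc(Br)ccc3c2)c2ccc(Cl)cc2)s1)c1ccc2c(c1)CCO2`, differs from compound 3 by a group of 9 heavy atoms (8 carbon, 1 oxygen; one five-membered non-aromatic ring with 1 hetero atom, one six-membered aromatic ring of carbon only) in place of a group of 7 heavy atoms (5 carbon, 1 nitrogen, 1 chlorine; one six-membered aromatic ring with 1 hetero atom), on a sulfonyl sulfur. Among the measured compounds shown here, no measured step bears on this change, so no direction or size beyond the scatter can be read for it in this assay. Given that compound 1 and compound 2 both sit at the limit and compound 3 is reported as not toxic, compound 4 is expected to remain similarly tolerated, estimated at 60000 nM, within 25000 nM to 150000 nM.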

Compound 4, half-maximal cytotoxic concentration: > 50000 nM
Compound 4: a limit, no number; the forecaster's own chance of this, stated with the estimate: 75%; the middle value is on the limit's open side.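

Compound 4, like compound 1 and compound 2, gives only a limit and not a number, so the steps among these three compounds cannot be read. The compounds shown leave open whether the group on the sulfonyl sulfur changes the result in this assay at all, as all that can be seen is this: the limit of > 50000 nM in this assay, at which 3 of the 4 values shown sit.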